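A few compounds are considered here, and "the series" means these few. Any claim that something is new, unique, unknown or untested is made for them only; others in the source may bear on it.

Notes on the amide side chain, with the shared core held constant. In a functional assay on MCF7 cells (Homo sapiens) for antiproliferative activity, read by MTT assay, with a stated time of 24 h (on this read-out lower numbers stand for stronger inhibition and higher numbers for weaker inhibition), compound 2 `CCn1c(C(=O)N[C@@H](C)CO)ccc1C(CC)(CC)c1ccc(OCS(=O)(=O)c2ccccc2)c(C)c1` gives 10800 nM and compound 3 `CCn1c(C(=O)NC2(CO)CC2)ccc1C(CC)(CC)c1ccc(OCS(=O)(=O)c2ccccc2)c(C)c1` gives 28800 nM, the higher of these two numbers. Compound 1 `CCn1c(C(=O)N[C@H](C)C(=O)OC)ccc1C(CC)(CC)c1ccc(OCS(=O)(=O)c2ccccc2)c(C)c1` reports only a limit, > 50000 nM.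

Compound 4 `CCn1c(C(=O)NCCCO)ccc1C(CC)(CC)c1ccc(OCS(=O)(=O)c2ccccc2)c(C)c1` carries 3-hydroxypropyl in place of 1-(hydroxymethyl)cyclopropyl on an amide-type nitrogen.

The closest measured change is a 2.7-fold higher number from compound 2 to compound 3 (0.43 log units; beyond the scatter), where the cyclopropyl-containing group gave the higher number. The steps of an at least 4.6-fold lower number from compound 1 to compound 2 (0.66 log units; beyond the scatter) and an at least 1.7-fold lower number from compound 1 to compound 3 (0.23 log units; that floor lies within the scatter) start from a limit and give only floors, so they bear less on this change. A modest move to a lower number is expected in this assay, the estimated step being a 1.8-fold lower number from compound 3 to compound 4 (0.26 log units; within the scatter). For compound 4 the estimate is 16000 nM, with an expected range of 7000 nM to 38000 nM.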

Compound 4, half-maximal inhibitory concentration: 42000 nM
For compound 4 the middle estimate is 2.6-fold (0.42 log units) below the measured one; the measured number lies above the stated range.
By their numbers in this assay, from the lowest: compound 2; then compounds 3 and 4 (each within the scatter of the next). At a limit, above all of these: compound 1.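

In this assay, 3-hydroxypropyl in place of 1-(hydroxymethyl)cyclopropyl on the amide-type nitrogen gives a 1.5-fold higher number from compound 3 to compound 4 (0.16 log units; within the scatter), so the open-chain group and the ring-bearing group cannot be told apart here. Against 1-(hydroxymethyl)ethyl, the 3-hydroxypropyl group fares worse, with a 3.9-fold higher number from compound 2 to compound 4 (0.59 log units; beyond the scatter). Compound 1 stands at a limit: the limit of > 50000 nM in this assay, at which 1 of the 4 values shown sits. Read from that limit, the remaining step gives only a floor: an at least 1.1-fold lower number from compound 1 to compound 4 (0.07 log units; that floor lies within the scatter).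

Going by these compounds, whether a longer chain, or an amine or a carboxylic acid in place of the hydroxyl, would bring the number down stays open.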